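Moving the hydroxyethyl chain around a morpholine amide

The compounds below may be only part of what the source reports. "The series", "measured", "known", "first", "only" and "open" are said of these compounds alone.

Of the compounds shown here, three sharing one core have been tested in an assay on isolated protein for inhibition of thyroid hormone receptor beta (Homo sapiens), read by fluorescence, with a stated time of 30 min; on this read-out lower numbers stand for stronger inhibition and higher numbers for weaker inhibition. Compound 1 `COc1cc(C(=O)N2CC[C@@H](O)[C@H](C)C2)cc2nc(NCc3cccc(Cl)c3)oc12` gives 10 nM, while its mirror image, compound 2 `COc1cc(C(=O)N2CC[C@H](O)[C@@H](C)C2)cc2nc(NCc3cccc(Cl)c3)oc12`, gives 120 nM. The step of a 12-fold higher number from compound 1 to compound 2 (1.08 log units; beyond the scatter) is large, and its only structural basis is the fact that compounds 1 and 2 differ only in the configuration as drawn, so the configuration at the saturated ring carbons of the amide-bearing ring clearly matters on this read-out. Compound 3 `COc1cc(C(=O)N2CC(C)(CCO)OC[C@H]2C)cc2nc(N[C@H](C)c3cccc(Cl)c3)oc12` gives 0.5 nM, the lowest number of the three, and stands apart from both earlier compounds by more than the usual scatter.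

Compound 4 `COc1cc(C(=O)N2C[C@H](C)OC[C@@H]2CCO)cc2nc(N[C@H](C)c3cccc(Cl)c3)oc12` keeps the same core and the same side chain on the other end, and differs from compound 3 only in the amide-bearing ring: 5-(2-hydroxyethyl)-2-methylmorpholin-4-yl in place of 2-(2-hydroxyethyl)-2,5-dimethylmorpholin-4-yl on a carbonyl carbon. Among the measured compounds shown here, no measured step covers exactly this rearrangement of a hydroxyethyl and a methyl group around the ring. For the measured compounds named here, the one step available, from compound 1 to compound 2, concerns configuration at ring carbons of a related saturated ring, and its size suggests that reshuffling substituents there can shift the number well beyond the scatter, most likely upward from the low value of compound 3. Compound 4 is therefore expected to give 2.5 nM, within 0.4 nM to 15 nM, a step of a 5.0-fold higher number from compound 3 to compound 4 (0.70 log units; beyond the scatter).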

Compound 4, half-maximal inhibitory concentration: 4 nM
The estimate for compound 4 lay 1.6-fold (0.20 log units) below the measured number, and the stated range covers the measured number.
By their numbers in this assay, from the lowest: compound 3; then compound 4; then compound 1; then compound 2.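

The change of the group on the carbonyl carbon gives an 8.0-fold higher number from compound 3 to compound 4 (0.90 log units; beyond the scatter), so the number in this assay responds to how substituents are arranged around this amide-bearing ring as well as to their configuration. The step occurs although both groups contain one six-membered non-aromatic ring with the same counts of hydrogen-bond donors and acceptors and no net charge, so those counts alone do not settle the number here. The earlier compounds spoke only to configuration, in a different saturated ring, and the step between them is printed as large while this one is printed as modest, but the only fact on record about them is structural: the fact that compounds 1 and 2 differ only in the configuration as drawn

This single step combines a moved hydroxyethyl chain, one methyl group fewer and a different number of defined stereocentres, and the compounds shown cannot separate these contributions. Also open, going by these compounds, is how the number would respond if the hydroxyethyl chain gave way to a longer hydroxypropyl chain, or if its hydroxyl were replaced by an amine or a carboxylic acid.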